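The source may hold more compounds than are shown below. What is called first, only, known or untested is meant among the compounds shown, and "the series" means these compounds.

Compound 1 `COc1cc(O)c(C(=O)c2ccccc2Br)c(OC)c1` is one of three measured compounds built on a shared core. In a functional assay on THP-1 cells (Homo sapiens) for inhibition, read by ELISA, with stated times of 30 min and 24 h, tested at 1 uM (a higher number here means a stronger effect of the compound at the concentration tested, a lower number a weaker effect), compound 1 gives 7%, the lowest of the three numbers. Compound 2 `COc1cc(OC)c(C(=O)c2ccccc2Br)c(O)c1CN1CCCCC1` gives 22%, and compound 3 `COc1cc(OC)c(C(=O)c2ccccc2Br)c(O)c1CN1CCCC1` gives 19%. Both measured steps leading away from compound 1 change the same place on the core: a number 15 percentage points higher from compound 1 to compound 2 (beyond the scatter) and a number 12 percentage points higher from compound 1 to compound 3 (beyond the scatter), each beyond the scatter, while between the two larger compounds a number 3 percentage points lower from compound 2 to compound 3 (within the scatter). Compound 4 `COc1cc(O)c(C(=O)c2ccccc2F)c(OC)c1` has not yet been measured. It differs from compound 1 at a different place: fluoro in place of bromo on an aromatic carbon. Going by the values given here, none of the measured steps touches this halogen, so none of them bears directly on the new step; the only guide is that compound 1, which carries the bromo, already stands at the bottom of the numbers and leaves little room to fall. The step is therefore expected to stay within the scatter, as a number 1 percentage points lower from compound 1 to compound 4 (within the scatter). Compound 4 is estimated to give 6%, within a range from 0% to 18%.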

Compound 4, a percentage reported as activity, at one concentration (the size of the read-out at that concentration, not a potency): 11%
For compound 4 the middle estimate is 5 percentage points below the measured one; low and high end bracket the measured number.
By their numbers in this assay, from the lowest: compounds 1, 4, 3 and 2 (each within the scatter of the next, the first and the last beyond it).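

Fluoro in place of bromo on an aromatic carbon, ortho to a large group, is the first change shown at this position, and it comes out as a number 4 percentage points higher from compound 1 to compound 4 (within the scatter) in this assay at the one concentration tested. Exchanging one halogen for the other therefore produces no readable change here, whereas adding a group elsewhere on the shared core gave a number 15 percentage points higher from compound 1 to compound 2 (beyond the scatter) in the same test. Nothing measured here helps to explain this result.

As far as these compounds go, whether a group other than a halogen at this position, such as an amine, a nitrile or a carboxylic acid, would move the number remains open. So does the question of whether fluoro combined with (piperidin-1-yl)methyl would give the same reading as bromo combined with that group.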